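Phenyl to Methyl on the Amide Carbonyl of a Chalcone

The compounds below may be only part of what the source reports. "The series", "measured", "known", "first", "only" and "open" are said of these compounds alone.

Compound 2 `COc1cc(/C=C/C(=O)c2cccc(NC(=O)c3ccccc3)c2)ccc1O` stands second among the three measured compounds in a functional assay on HUVEC cells (Homo sapiens) for inhibition, tested at 5 ug/mL (on this read-out higher numbers stand for a stronger effect at the one concentration tested and lower numbers for a weaker effect), where compound 2 gives 48%. Above it, compound 1 `COc1cc(/C=C/C(=O)c2cccc(NC(=O)c3ccco3)c2)ccc1O` in this assay gives 82%; below it, compound 3 `COC(=O)C(=O)Nc1cccc(C(=O)/C=C/c2ccc(O)c(OC)c2)c1` in this assay gives 20%. The two neighbouring steps both run downward: a number 34 percentage points lower from compound 1 to compound 2 (beyond the scatter) and a number 28 percentage points lower from compound 2 to compound 3 (beyond the scatter), which together add up to a number 62 percentage points lower from compound 1 to compound 3 (beyond the scatter).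

Compound 4 `COc1cc(/C=C/C(=O)c2cccc(NC(C)=O)c2)ccc1O` is reached from compound 2 by the change (methyl in place of phenyl on a carbonyl carbon). Among the compounds with values here, no measured step removes a ring from this carbonyl carbon, so the relevant comparisons are indirect. The two groups bearing a ring, furan-2-yl and phenyl, give the higher numbers, while methoxycarbonyl, which has no ring, gives the lowest. Methyl, also without a ring, resembles the latter case more than the former. A downward step beyond the scatter is therefore expected in this assay, of roughly the size seen from compound 2 to compound 3, with a wide range on either side.

Compound 4 is thus expected to give about 30% in this assay, within a range from 10% to 55%. This estimate corresponds to an expected step of a number 18 percentage points lower from compound 2 to compound 4 (beyond the scatter).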

Compound 4, a percentage reported as inhibition, at one concentration (the size of the read-out at that concentration, not a potency): 15%
Compound 4: middle estimate off by 15 percentage points, on the high side; measured number inside the range.
By their numbers in this assay, from the lowest: compounds 4 and 3 (each within the scatter of the next); then compound 2; then compound 1.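

Methyl on this carbonyl carbon, a single carbon with no ring, falls with methoxycarbonyl rather than with the two groups bearing a ring. In this assay, the replacement of methoxycarbonyl by methyl gives (a number 5 percentage points lower from compound 3 to compound 4 (within the scatter)), whereas the replacement of phenyl gives (a number 33 percentage points lower from compound 2 to compound 4 (beyond the scatter)) and that of furan-2-yl gives (a number 67 percentage points lower from compound 1 to compound 4 (beyond the scatter)). Where earlier a single group without a ring stood at the low end, there are now two that cannot be told apart, and among these four compounds none goes against the split between groups with a ring and groups without one; nothing measured alongside these numbers accounts for that split.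

The compounds shown leave open whether a saturated ring such as cyclohexyl, or a longer chain such as n-butyl, would join the groups with a ring or the groups without one. They also leave open whether the gap between furan-2-yl and phenyl extends to other rings, such as thiophen-2-yl or pyridin-3-yl, on this same carbonyl carbon.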